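Swapping the Piperazine for Hydroxy on the Propyl Chain

The source may report more compounds than this note shows. Statements on the series, on what has been measured and on what is new or still open speak of the compounds shown alone.

Measured in a functional assay on A549 cells (Homo sapiens) for antiproliferative activity, read by MTT assay, with a stated time of 48 h; on this read-out higher numbers stand for weaker inhibition and lower numbers for stronger inhibition:
- Compound 1 `CN1CCN(CCn2c(N)c(-c3nc4ccccc4[nH]3)c3nc(C#N)c(C#N)nc32)CC1`: 40500 nM
- Compound 2 `CN(C)CCCn1c(N)c(-c2nc3ccccc3[nH]2)c2nc(C#N)c(C#N)nc21`: 10400 nM
- Compound 3 `CN1CCN(CCCn2c(N)c(-c3nc4ccccc4[nH]3)c3nc(C#N)c(C#N)nc32)CC1`: 5750 nM

Compound 3 has the lowest number of the three, though a 1.8-fold lower number from compound 2 to compound 3 (0.26 log units; within the scatter) lies within the scatter, so compound 2 and compound 3 cannot be told apart. Only compound 1 clearly sits higher, as a 7.0-fold lower number from compound 1 to compound 3 (0.85 log units; beyond the scatter) shows.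

The next compound is compound 4 `N#Cc1nc2c(-c3nc4ccccc4[nH]3)c(N)n(CCCO)c2nc1C#N`, and the change is hydroxy in place of 4-methylpiperazin-1-yl on a saturated chain carbon, three bonds along the chain from an aromatic nitrogen: hydroxy in place of 4-methylpiperazin-1-yl, so 3-(4-methylpiperazin-1-yl)propyl becomes 3-hydroxypropyl.

The nearest evidence is a 1.8-fold lower number from compound 2 to compound 3 (0.26 log units; within the scatter), where one nitrogen-bearing group replaced another at this same place with no change beyond the scatter. The steps of a 3.9-fold lower number from compound 1 to compound 2 (0.59 log units; beyond the scatter) and a 7.0-fold lower number from compound 1 to compound 3 (0.85 log units; beyond the scatter) are modest, but each also alters the chain. Within the data shown here, no measured compound carries hydroxy here, so this swap goes beyond anything tested and the forecast is uncertain. A modest move toward weaker inhibition seems the likeliest outcome in this assay, with no change also possible.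

The expected result is a 2.4-fold higher number from compound 3 to compound 4 (0.39 log units; beyond the scatter). For compound 4 the estimated value is 14000 nM, with an expected range from 4000 nM to 50000 nM.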

Compound 4, half-maximal inhibitory concentration: > 50000 nM
Compound 4 gave a limit, no number; the forecaster's own chance of this, stated with the estimate: 15%; middle value at least 3.5-fold (0.55 log units) away from the limit.
By their numbers in this assay, from the lowest: compounds 3 and 2 (each within the scatter of the next); then compound 1. At a limit, above all of these: compound 4.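

Compound 4 is reported only as a limit of the assay, not as a number: the limit of > 50000 nM in this assay, at which 1 of the 4 values shown sits.

Among these compounds, the earlier compounds showed only that two nitrogen-bearing groups at the end of the propyl chain, dimethylamino and 4-methylpiperazin-1-yl, could not be told apart, as a 1.8-fold lower number from compound 2 to compound 3 (0.26 log units; within the scatter) makes clear, whereas hydroxy at this place clearly gives weaker inhibition, with an at least 8.6-fold higher number from compound 3 to compound 4 (0.93 log units; beyond the scatter) and an at least 4.8-fold higher number from compound 2 to compound 4 (0.68 log units; beyond the scatter). Compound 1 is not separated from this result, since an at least 1.2-fold higher number from compound 1 to compound 4 (0.09 log units; that floor lies within the scatter) gives only a floor, so no order can be stated for that pair.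

The limit leaves open how much weaker the inhibition of the 3-hydroxypropyl compound really is, and the compounds shown cannot tell whether what matters is the arrival of hydroxy or the loss of a nitrogen-bearing group. A primary amine or a methoxy group at the same place on the propyl chain would help to separate these two readings, and a morpholin-4-yl group would test whether a ring oxygen in place of the ring nitrogen is tolerated.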